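Azetidin-1-yl in place of the arylamino group

This account rests on a few compounds, and the source may have more. Where it says the series, first, only, none or still open, it means among the compounds named here.

Among the measured compounds shown here, in a functional assay on ECa-109 cells for inhibition, with ECa-109 cell line (Homo sapiens) as the target, read by sulforhodamine B assay (on this read-out lower numbers stand for stronger inhibition and higher numbers for weaker inhibition), compound 2 (`COc1ccc(NC2=CC(=O)c3c(nc4n3[C@H]3OC[C@@H](O)[C@H]3OC4)C2=O)cc1`) gives 3410 nM, the only actual number so far in this small series. Compound 1 (`O=C1C(N2CCCCC2)=CC(=O)c2c1nc1n2[C@H]2OC[C@@H](O)[C@H]2OC1`) gives > 8000 nM, which is a limit of the assay and not a number.

For the measured compounds named here, the one measured step is an at least 2.3-fold lower number from compound 1 to compound 2 (0.37 log units; beyond the scatter), with (4-methoxyphenyl)amino in place of piperidin-1-yl on a double-bonded ring carbon. Going by these compounds, its full size stays open, given (the limit of > 8000 nM in this assay, at which 1 of the 2 values shown sits).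

Compound 3 (`O=C1C(N2CCC2)=CC(=O)c2c1nc1n2[C@H]2OC[C@@H](O)[C@H]2OC1`) carries azetidin-1-yl in place of (4-methoxyphenyl)amino at that same kind of carbon: azetidin-1-yl in place of (4-methoxyphenyl)amino on a double-bonded ring carbon. The entering group, like the piperidin-1-yl of compound 1, is a non-aromatic ring, and the (4-methoxyphenyl)amino group that gave the lower number in compound 2 is lost. The step to compound 2, an at least 2.3-fold lower number from compound 1 to compound 2 (0.37 log units; beyond the scatter), is therefore expected to be largely undone, which points to higher numbers in this assay by a similar size. The estimated change is a 2.3-fold higher number from compound 2 to compound 3 (0.37 log units; beyond the scatter). For compound 3 the expected value is 8000 nM, with an estimated range of 3500 nM to 20000 nM.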

Compound 3, half-maximal inhibitory concentration: > 16000 nM
Compound 3 gave a limit, no number (the forecaster's own chance of this, stated with the estimate: 50%); middle value at least 2.0-fold (0.30 log units) from the limit.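

In this assay, azetidin-1-yl in place of (4-methoxyphenyl)amino on a double-bonded ring carbon gives an at least 4.6-fold higher number from compound 2 to compound 3 (0.67 log units; beyond the scatter), the first measured step away from compound 2 with a ring other than piperidin-1-yl entering. Compound 1 and compound 3, both with a non-aromatic ring on this carbon, now end in limits, while compound 2 alone has a number, and none of the three goes against this pattern. Compound 3 gives > 16000 nM, which is a limit of the assay and not a number, and the step between compound 1 and compound 3 cannot be read, so no order of the two non-aromatic rings can be stated: the limit of > 16000 nM in this assay, at which 1 of the 3 values shown sits.

Going by these compounds, it remains open which part of the (4-methoxyphenyl)amino group goes with the lower number, and a plain phenylamino group or a benzylamino group on this carbon would begin to separate the methoxy group, the aromatic ring and the amine hydrogen. A cyclohexylamino group would show whether an amine hydrogen without an aromatic ring stays near compound 2 or falls with compound 1 and compound 3.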